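This account rests on a few compounds, and the source may have more. Where it says the series, first, only, none or still open, it means among the compounds named here.

Working notes on the series in an assay on HEK293 cells for displacement of a labelled ligand from prostaglandin D2 receptor 2 (Homo sapiens); a higher number here means a weaker inhibitor, a lower number a stronger inhibitor.

Three compounds have numbers. Compound 1, `O=C(O)Cn1c(SCCOc2ccc3ccccc3c2)nc2ccccc21`, gives 2500 nM. Compound 2, `O=C(O)Cn1c(SCCOc2cccc3ccccc23)nc2ccccc21`, gives 2000 nM. Compound 3, `CCCCCCSc1nc2ccccc2n1CC(=O)O`, gives 1360 nM. Compound 3 has the lowest of the three numbers, but its gap to compound 2 and its gap to compound 1 both sit within the usual scatter, so no ordering among the three can be read from these values, and compound 3 cannot be called the strongest on this evidence.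

Compound 4, `CCOC(=O)CCCCCSc1nc2ccccc2n1CC(=O)O`, has not been measured. It differs from compound 3 in one place: ethoxycarbonyl in place of methyl on a saturated chain carbon, five bonds along the chain from a sulfur. The chain that carries the sulfur is otherwise the same.

Among the compounds with values here, no step between measured compounds with a comparable change is available, so the expectation rests on the change alone. The step from compound 3 to compound 4 is expected to be small, most likely toward a higher number, and possibly not beyond the scatter, a 1.6-fold higher number from compound 3 to compound 4 (0.21 log units; within the scatter). For compound 4 the expected value in this assay is 2200 nM, within a range from 800 nM to 6000 nM.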

Compound 4, half-maximal inhibitory concentration: 1010 nM
Compound 4: middle estimate off by 2.2-fold (0.34 log units), on the high side; the range from low to high includes it.
By their numbers in this assay, from the lowest: compounds 4, 3, 2 and 1 (each within the scatter of the next, the first and the last beyond it).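

In this assay, putting ethoxycarbonyl in place of methyl on a saturated chain carbon, five bonds along the chain from a sulfur, gives a 1.3-fold lower number from compound 3 to compound 4 (0.13 log units; within the scatter) and this step lies within the scatter. This position therefore accepts a group of five heavy atoms with two hydrogen-bond acceptors in place of a single carbon, with no change that can be read, so compound 3 and compound 4 cannot be told apart on this evidence. No measurement at hand offers an explanation for this result.

As far as these compounds go, whether an amine or a primary amide at this same place would move the number beyond the scatter stays open. From the compounds shown here alone, it also stays open whether the free carboxylic acid in place of the ethyl ester would keep the number level with compound 3.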